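The source may hold more compounds than are shown below. What is called first, only, known or untested is meant among the compounds shown, and "the series" means these compounds.

Compound 1, `COc1ccc(-c2ccc(-c3ccc(C(=N)N)o3)o2)cc1`, 36.3%; compound 2, `COc1ccc(-c2ccc(-c3ccc(C(=N)N)s3)s2)cc1`, 63.7%; compound 3, `N=C(N)c1ccc(-c2ccc(-c3cncc4ccccc34)s2)s1`, 4%.

All three were tested in an ADME assay on cells (Erythrocyte, Homo sapiens) for activation, read by hemolysis, with a stated time of 30 min, tested at 5 mM; a lower number here means a weaker effect, a higher number a stronger effect of the compound at the concentration tested. Compound 1 gives 36.3%, the second highest of the three numbers; compound 2 lies higher by a gap beyond the usual scatter, and compound 3 lies lower by a gap that is also beyond the scatter. Compound 4, `N=C(N)c1ccc(-c2ccc(-c3ccccc3)o2)o1`, has not been measured yet. It differs from compound 1 in one place: hydrogen in place of methoxy on an aromatic carbon. Going by the values given here, no two measured compounds differ in only one place, so there is no measured step to lean on. In this assay the expected change is a slight decrease that may well stay within the scatter, a number 6.3 percentage points lower from compound 1 to compound 4 (within the scatter). For compound 4 the estimate in this assay is 30%, with a range from 10% to 55%.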

Compound 4, a percentage reported as activity, at one concentration (the size of the read-out at that concentration, not a potency): 30.1%
Compound 4: the middle estimate sits 0.1 percentage points below what was measured, within the range that was stated.
By their numbers in this assay, from the lowest: compound 3; then compounds 4 and 1 (each within the scatter of the next); then compound 2.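

In this assay, going by these compounds alone, hydrogen in place of methoxy on an aromatic carbon, para to a large group, gives a number 6.2 percentage points lower from compound 1 to compound 4 (within the scatter) and this is the first measured step at a single place. The methoxy group is therefore not required at this position for the read-out to stay at this level, since the hemolysis seen with it remains once hydrogen stands there. Nothing shown here explains this result.

As far as these compounds go, whether an amine or a carboxylic acid on this same aromatic carbon would shift the number beyond the scatter remains open. So does whether the same change on compound 2 would give a similarly small step.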